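Cyclopropyl to (dimethylamino)methyl: compound 3 to compound 4

A few compounds are considered here, and "the series" means these few. Any claim that something is new, unique, unknown or untested is made for them only; others in the source may bear on it.

Three compounds carry numbers in a functional assay on CHO-K1 cells for antagonist activity at C-X-C chemokine receptor type 3 (Homo sapiens), read by FLIPR, with a stated time of 10 min; a higher number here means a weaker inhibitor, a lower number a stronger inhibitor. Compound 1 `Cn1c(CN2CCN(c3ccccc3NC(=O)c3ccco3)CC2)nc2ccccc21` gives 372 nM and compound 2 `O=C(Cn1cnc2cccnc21)N1CCN(c2ncccc2-c2nc3ccccc3[nH]2)CC1` gives 496 nM; compound 3 `C[C@@H]1CN(c2sc(C3CC3)nc2-c2nc3ccccc3[nH]2)CCN1C(=O)Cn1cnc2cccnc21` gives 9.7 nM, the lowest of the three, with compound 1 and compound 2 both lying beyond the scatter higher. Within the data shown here, no pair of measured compounds differs in a single place, so no measured step is at hand. Compound 4 `C[C@@H]1CN(c2sc(CN(C)C)nc2-c2nc3ccccc3[nH]2)CCN1C(=O)Cn1cnc2cccnc21` differs from compound 3 by (dimethylamino)methyl in place of cyclopropyl on an aromatic carbon. Among the measured compounds shown here, with no measured step of this kind, a small shift toward a higher number is expected, a 2.1-fold higher number from compound 3 to compound 4 (0.31 log units; beyond the scatter), close to the edge of the scatter. Compound 4 is thus estimated at 20 nM in this assay, within 5 nM to 80 nM.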

Compound 4, half-maximal inhibitory concentration: 50 nM
Beside the measured number, compound 4's estimate is 2.5-fold (0.40 log units) below it; measured number inside the range.
By their numbers in this assay, from the lowest: compound 3; then compound 4; then compounds 1 and 2 (each within the scatter of the next).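

Among these compounds, this is the first single-place step: in this assay, a 5.2-fold higher number from compound 3 to compound 4 (0.71 log units; beyond the scatter), so the aromatic carbon between the ring nitrogen and ring sulfur is sensitive to this change, though only modestly. An open-chain group bearing a hydrogen-bond acceptor is therefore accepted here at a modest cost relative to cyclopropyl. No available measurement accounts for the step.

This step swaps a ring for an open chain and adds a nitrogen at once, leaving the two changes inseparable. On these data alone, how an isopropyl or a pyrrolidin-1-ylmethyl group would read at this carbon remains open.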